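Lipoyl-triazole coumarin series: aryl replacement at the coumarin ring

The source may hold more compounds than are shown below. What is called first, only, known or untested is meant among the compounds shown, and "the series" means these compounds.

Measured so far in a functional assay on PC-12 cells (Rattus norvegicus) for cytotoxicity, read by MTT assay, with stated times of 3 h and 2 h, tested at 1 uM; on this read-out lower numbers stand for a weaker effect and higher numbers for a stronger effect at the one concentration tested:
- compound 1, `CCOC(=O)c1cc2ccc(OCCCn3cc(CNC(=O)CCCCC4CCSS4)nn3)cc2oc1=O`: 28.3%
- compound 2, `O=C(CCCCC1CCSS1)NCc1cn(CCCOc2ccc3cc(-c4ccc(Cl)cc4)c(=O)oc3c2)nn1`: 49.3%
- compound 3, `CCOC(=O)c1cc2ccc(OCCCCCn3cc(CNC(=O)CCCCC4CCSS4)nn3)cc2oc1=O`: 35.1%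

Compound 3 stands second highest of the three numbers; its gap to compound 1 lies within the scatter, while compound 2 sits beyond the scatter above it. The step from compound 3 to compound 4, `COc1ccc(-c2cc3ccc(OCCCCCn4cc(CNC(=O)CCCCC5CCSS5)nn4)cc3oc2=O)cc1OC`, is 3,4-dimethoxyphenyl in place of ethoxycarbonyl on an aromatic carbon. Within the data shown here, the one measured step bearing on it is a number 21 percentage points higher from compound 1 to compound 2 (beyond the scatter), where an aromatic ring likewise replaced the ethoxycarbonyl at this position. A rise of comparable size in this assay is therefore expected for compound 4, namely a number 17.9 percentage points higher from compound 3 to compound 4 (beyond the scatter). Compound 4 is estimated at 53%, within 40% to 66%.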

Compound 4, a percentage reported as activity, at one concentration (the size of the read-out at that concentration, not a potency): 42.2%
Compound 4: middle estimate off by 10.8 percentage points, on the high side; the measured number falls inside the stated range.
By their numbers in this assay, from the lowest: compounds 1, 3, 4 and 2 (each within the scatter of the next, the first and the last beyond it).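

In this assay the change from ethoxycarbonyl to 3,4-dimethoxyphenyl on this aromatic carbon gives a number 7.1 percentage points higher from compound 3 to compound 4 (within the scatter) and does not clear the scatter, whereas the change to 4-chlorophenyl gave a number 21 percentage points higher from compound 1 to compound 2 (beyond the scatter) on the other chain. A rise beyond the scatter on losing ethoxycarbonyl therefore does not hold across both pairs, and compound 4 goes against it. No measurement shown accounts for this result.

The two pairs differ in both aryl group and chain, so either may underlie the contrast. A 4-chlorophenyl group on the chain of compound 3, or a carboxylic acid at this carbon, would help separate them.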